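Alkoxy-aminoquinoline analogues at the melanin-concentrating hormone receptor

A few compounds are considered here, and "the series" means these few. Any claim that something is new, unique, unknown or untested is made for them only; others in the source may bear on it.

Measured so far:
Compound 1 `CC1CCCCC1Oc1cccc2ccc(N)nc12` — 32 nM
Compound 2 `CCC(C)COc1cccc2ccc(N)nc12` — 36 nM
Compound 3 `CCCC(C)Oc1cccc2ccc(N)nc12` — 105 nM

In an assay on cells with melanin-concentrating hormone receptor 1 (Homo sapiens) as the target, read by radioligand binding (on this read-out lower numbers stand for stronger inhibition and higher numbers for weaker inhibition), compound 2 gives 36 nM, the second highest of the three numbers; compound 1 sits within the scatter of it, while compound 3 lies beyond it. Compound 4 `COCC(C)Oc1cccc2ccc(N)nc12` is not yet measured. It differs from compound 2 as follows: 1-(methoxymethyl)ethyl in place of 2-methylbutyl on an oxygen on an aromatic ring. Among the compounds with values here, the only measured step that touches the same oxygen is a 2.9-fold higher number from compound 2 to compound 3 (0.46 log units; beyond the scatter), where the chain was reshaped without changing its size. Compound 4 also reshapes the chain and swaps one carbon for an oxygen. The expectation for compound 4 is therefore a 4.2-fold higher number from compound 2 to compound 4 (0.62 log units; beyond the scatter), a weaker result than compound 2, estimated at 150 nM with a range from 50 nM to 450 nM.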

Compound 4, half-maximal inhibitory concentration: 606 nM
Beside the measured number, compound 4's estimate is 4.0-fold (0.61 log units) below it; measured number outside the range, above it.
By their numbers in this assay, from the lowest: compounds 1 and 2 (each within the scatter of the next); then compound 3; then compound 4.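

In this assay, the position on the oxygen proves sensitive to more than the shape of the chain: methoxy in place of ethyl gives a 5.8-fold higher number from compound 3 to compound 4 (0.76 log units; beyond the scatter) even though 1-(methoxymethyl)ethyl has the same number of heavy atoms as 2-methylbutyl. Together with the reshaped chain, this makes a 17-fold higher number from compound 2 to compound 4 (1.23 log units; beyond the scatter) and the largest step in the set. Nothing available explains this loss.

The compounds shown leave open whether an amine or a hydroxyl group in the same chain would behave like methoxy. A longer ether chain is equally untested here.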